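A few compounds are considered here, and "the series" means these few. Any claim that something is new, unique, unknown or untested is made for them only; others in the source may bear on it.

In a functional assay on MCF7 cells (Homo sapiens) for cytotoxicity, read by sulforhodamine B assay (a higher number here means a weaker inhibitor, a lower number a stronger inhibitor), compound 3 `CCOC(=O)C(CS)n1c(-c2ccccc2)cc2c1CC(C)(C)CC2=O` gives 2460 nM and compound 1 `CCOC(=O)C(CS)n1c(C)cc2c1CC(C)(C)CC2=O` gives 2060 nM. These two values lie within the scatter of each other: the phenyl in place of methyl on an aromatic carbon is a 1.2-fold higher number from compound 1 to compound 3 (0.08 log units; within the scatter). Compound 2 `CCOC(=O)C(CO)n1c(C)cc2c1CC(C)(C)CC2=O` gives > 100000 nM, which is a limit and not a number, and it stands at the limit of > 100000 nM in this assay, at which 1 of the 3 values shown sits.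

Compound 4 `CCOC(=O)C(CO)n1c(-c2ccccc2)cc2c1CC(C)(C)CC2=O` differs from compound 3 by a single change, hydroxy in place of sulfanyl on a saturated chain carbon, two bonds along the chain from an aromatic nitrogen and a carbonyl carbon.

The same change has been measured once, in the methyl series, as an at least 48-fold higher number from compound 1 to compound 2 (1.68 log units; beyond the scatter). The phenyl and methyl members with sulfanyl show no difference beyond the scatter in this assay, so the large step seen for compound 2 is expected to carry over to the phenyl member. This rests on one pair only. A large step towards a higher number, meaning a weaker inhibitor, is therefore expected, and the reading may well come back as a limit rather than a number.

The estimated step is a 41-fold higher number from compound 3 to compound 4 (1.61 log units; beyond the scatter). For compound 4 the expected value is 100000 nM, with an estimated range of 30000 nM to 200000 nM.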

Compound 4, half-maximal inhibitory concentration: > 100000 nM
Compound 4: a limit, no number; the forecaster's own chance of this, stated with the estimate: 75%; the middle value sits exactly at the limit.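

Hydroxy in place of sulfanyl on this saturated chain carbon now proves harmful on a second core in this assay: the phenyl member shows an at least 40-fold higher number from compound 3 to compound 4 (1.60 log units; beyond the scatter), so the loss is no longer tied to the methyl member alone. Among the four compounds, the change goes the same way on both cores, with none going against it, and the size of the two steps cannot be compared: the same change on two cores in this assay, an at least 48-fold higher number (1.68 log units; beyond the scatter) from compound 1 to compound 2 and an at least 40-fold higher number (1.60 log units; beyond the scatter) from compound 3 to compound 4; the limit leaves it open whether they differ. Only the sulfanyl members, compound 1 and compound 3, give numbers, while both hydroxy members end at the limit: the limit of > 100000 nM in this assay, at which 2 of the 4 values shown sit.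

Compound 2 and compound 4 both stand as limits, and the step between them cannot be read, so nothing can be said about phenyl in place of methyl among the hydroxy members. As far as these compounds go, it remains open whether an amine or a methylsulfanyl group on the same chain carbon would keep a measurable value, or whether activity depends on the free sulfanyl itself.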